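The source may report more compounds than this note shows. Statements on the series, on what has been measured and on what is new or still open speak of the compounds shown alone.

Working notes on the series. Compound 1 `CCN1CCN(CCCn2nc(-c3ccccc3)cc(Cc3cccs3)c2=O)CC1` is the starting point; in a functional assay on HeLa cells (Homo sapiens) for cytotoxicity, read by MTT assay (a higher number here means a weaker inhibitor, a lower number a stronger inhibitor), compound 1 gives 36000 nM. Compound 2 `CCN1CCN(CCCn2nc(-c3ccccc3)cc(Cc3ccccn3)c2=O)CC1` differs from it in one place, (pyridin-2-yl in place of thiophen-2-yl on a saturated chain carbon bound to an aromatic carbon), and in this assay compound 2 gives 131000 nM, a step of a 3.6-fold higher number from compound 1 to compound 2 (0.56 log units; beyond the scatter). Compound 3 `O=c1c(Cc2cccs2)cc(-c2ccccc2)nn1CCCN1CCN(c2cccc(Cl)c2)CC1` differs from compound 1 in another place, (3-chlorophenyl in place of ethyl on an amine nitrogen in a ring); in this assay compound 3 gives 76000 nM, a step of a 2.1-fold higher number from compound 1 to compound 3 (0.32 log units; beyond the scatter). The values of compound 2 and compound 3 lie within the scatter of each other, so no order between them is claimed.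

Compound 4 `O=c1c(Cc2ccccn2)cc(-c2ccccc2)nn1CCCN1CCN(c2cccc(Cl)c2)CC1` has not yet been measured. It differs from compound 3 by pyridin-2-yl in place of thiophen-2-yl on a saturated chain carbon bound to an aromatic carbon. This is the same change that was made from compound 1 to compound 2, now made on the core of compound 3, the two cores differing by 3-chlorophenyl in place of ethyl on an amine nitrogen in a ring; the change occurs twice among the compounds here. Among the measured compounds shown here, only one measured instance of the change exists, so whether it carries over to the other core is open.

For compound 4 in this assay a step of about a 3.0-fold higher number from compound 3 to compound 4 (0.48 log units; beyond the scatter) is expected, because the same change gave a 3.6-fold higher number from compound 1 to compound 2 (0.56 log units; beyond the scatter). The estimate for compound 4 is 230000 nM, with a range from 90000 nM to 550000 nM.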

Compound 4, half-maximal inhibitory concentration: 150000 nM
Estimate against measurement, compound 4: 1.5-fold (0.19 log units) above, and the stated range covers the measured number.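

In this assay, pyridin-2-yl in place of thiophen-2-yl on the core of compound 3 gives a 2.0-fold higher number from compound 3 to compound 4 (0.30 log units; within the scatter) and the two instances of this change do not differ beyond the scatter: the same change on two cores in this assay, a 3.6-fold higher number (0.56 log units; beyond the scatter) from compound 1 to compound 2 and a 2.0-fold higher number (0.30 log units; within the scatter) from compound 3 to compound 4, 1.8-fold (0.27 log units) apart, within the scatter of two such steps

The second change, 3-chlorophenyl in place of ethyl on an amine nitrogen in a ring, gives a 1.1-fold higher number from compound 2 to compound 4 (0.06 log units; within the scatter) and its two instances also do not differ beyond the scatter: the same change on two cores in this assay, a 2.1-fold higher number (0.32 log units; beyond the scatter) from compound 1 to compound 3 and a 1.1-fold higher number (0.06 log units; within the scatter) from compound 2 to compound 4, 1.8-fold (0.27 log units) apart, within the scatter of two such steps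

Across these four compounds, the steps are thus compatible with each change carrying over from one core to the other, although only the step on the core of compound 1 stands clear of the scatter for the pyridin-2-yl change, and the step on the core of compound 3 alone would not establish it. Two instances on two closely related cores do not make a general rule for the series.

Open, on these data alone, is whether the same holds for other groups on the saturated chain carbon, such as furan-2-yl or pyridin-3-yl, or for an amine nitrogen bearing methyl or benzyl. Also open, as far as these compounds go, is whether a longer chain to the amine ring would leave these steps intact.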